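Oxadiazole for vinyl on a piperidine carboxanilide core

The source may hold more compounds than are shown below. What is called first, only, known or untested is meant among the compounds shown, and "the series" means these compounds.

Measured in an ADME assay on PC-3 cells (Homo sapiens) for cytotoxicity, read by WST assay, tested at 100 uM; a higher number here means more inhibition at the concentration tested (going by the name of the read-out), a lower number less inhibition:
Compound 1 `C=Cc1cccc(C(=O)N2CCCC(C(=O)Nc3ccc(Cl)cc3)C2)c1`: 0%
Compound 2 `O=C(Nc1ccc(Cl)cc1)C1CCCN(C(=O)c2ccc(-c3ccco3)cc2)C1`: 6%
Compound 3 `O=C(Nc1cccc(CN2CCCC2)c1)C1CCCN(C(=O)c2cc(C(F)(F)F)cc(C(F)(F)F)c2)C1`: 51%

Compound 1 sits at the low end of this small set. Compound 2 gives a number within the usual scatter of it, so the two cannot be told apart, while compound 3 lies far above both and differs from them at several places at once.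

Compound 4 `Cc1nc(-c2cccc(C(=O)N3CCCC(C(=O)Nc4ccc(Cl)cc4)C3)c2)no1` keeps the core of compound 1 and changes one group: 5-methyl-1,2,4-oxadiazol-3-yl in place of vinyl on an aromatic carbon

Going by the values given here, no measured pair isolates this kind of change, so there is no direct guide to its size. Both compounds that share the chloroanilide part of compound 4 give low numbers in this assay, and the account expects compound 4 to stay near them, with a step from compound 1 of a number 8 percentage points higher from compound 1 to compound 4 (within the scatter), not beyond the scatter. The estimate for compound 4 is 8%, expected to fall between 0% and 30%.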

Compound 4, a percentage reported as inhibition, at one concentration (the size of the read-out at that concentration, not a potency): 0%
Compound 4: the middle estimate sits 8 percentage points above what was measured; measured number inside the range.
By their numbers in this assay, from the lowest: compounds 1, 4 and 2 (each within the scatter of the next); then compound 3.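

With the shared core held fixed, 5-methyl-1,2,4-oxadiazol-3-yl in place of vinyl on this aromatic carbon gives no change at the digits printed from compound 1 to compound 4 (within the scatter) in this assay. Going by these compounds alone, this is the first single-place step in the set, and it shows that a five-membered aromatic ring with hetero atoms and hydrogen-bond acceptors can stand at this position without a step beyond the scatter. Nothing on hand explains this result. Still open, going by these compounds, is whether a carboxylic acid or a primary amine on this aromatic carbon would move the number. Also open, on these data alone, is which of the several differences from compound 1 goes with the higher number of compound 3.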